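The source may hold more compounds than are shown below. What is called first, only, known or untested is meant among the compounds shown, and "the series" means these compounds.

Measured compounds:
- compound 1 `COc1cccc(-n2cc(COc3c(/C=C\C(=O)O)ccc(OC)c3CC=C(C)C)nn2)c1`, in a functional assay on NCI-H322 cells (Homo sapiens) for cytotoxicity, read by MTT assay, with a stated time of 24 h (on this read-out higher numbers stand for weaker inhibition and lower numbers for stronger inhibition), compound 1 gives 25200 nM
- compound 2 `COc1ccc(/C=C\C(=O)O)c(OCc2cn(-c3ccccc3C(=O)N3CCC(O)C3)nn2)c1CC=C(C)C`, for which this assay records "not determined" (no result reported)

Within the data shown here, compound 1 stands as the only entry with a number; compound 2 has no result. Compound 3 `COc1ccc(/C=C\C(=O)O)c(OCc2cn(-c3ccc(C#N)cc3)nn2)c1CC=C(C)C` differs from compound 1 by 4-cyanophenyl in place of 3-methoxyphenyl on an aromatic nitrogen. No step between measured compounds is available, so nothing shown says how this change acts. Without such a guide, compound 3 is expected to lie near compound 1, the step of a 1.0-fold lower number from compound 1 to compound 3 (0.00 log units; within the scatter) not expected to go beyond the scatter in either direction. Compound 3 is estimated at 25000 nM, within 8000 nM to 80000 nM.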

Compound 3, half-maximal inhibitory concentration: 18600 nM
Compound 3: middle estimate off by 1.3-fold (0.13 log units), on the high side; the range from low to high includes it.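

In this assay, 4-cyanophenyl in place of 3-methoxyphenyl on the aromatic nitrogen gives a 1.4-fold lower number from compound 1 to compound 3 (0.13 log units; within the scatter) and so stays within the scatter. This first readable step at this position therefore does not separate these two substituted phenyl groups, which match in heavy atoms and hydrogen-bond acceptors. No measurement shown offers an explanation for this result. Still open, from the compounds shown here alone, is whether a different kind of group at this position, such as an amine on the phenyl ring or a longer chain in its place, would move the number beyond the scatter.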